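A few compounds are considered here, and "the series" means these few. Any claim that something is new, unique, unknown or untested is made for them only; others in the source may bear on it.

Measured compounds:
Compound 1, `CC[C@H](C)[C@H](N)CN(C(=O)[C@@H]1C[C@H]1c1cccc(Cl)c1)c1ccc(-c2ccccc2)cc1`, gives 2200 nM in a functional assay for agonist activity at G protein-coupled receptor 88 (Homo sapiens), read by HTRF and cAMP accumulation; on this read-out lower numbers stand for an effect already at smaller amounts and higher numbers for an effect only at larger amounts of compound.
Compound 2, `CC[C@H](C)[C@H](N)CN(C(=O)[C@@H]1C[C@H]1c1cncnc1)c1ccc(-c2ccccc2)cc1`, gives 19000 nM in this assay.

Among the compounds with values here, compound 2 stands at the higher of the two numbers so far; its only measured neighbour is compound 1, and the single measured step, an 8.6-fold higher number from compound 1 to compound 2 (0.94 log units; beyond the scatter), separates them beyond the scatter.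

Compound 3, `CC[C@H](C)[C@H](N)CN(C(=O)[C@@H]1C[C@H]1c1cccs1)c1ccc(-c2ccccc2)cc1`, has not yet been measured. It differs from compound 2 in one place: thiophen-2-yl in place of pyrimidin-5-yl on a saturated ring carbon. Within the data shown here, the only step that bears on this change is the one from compound 1 to compound 2, in which pyrimidin-5-yl came in for 3-chlorophenyl on the same saturated ring carbon and raised the number by an 8.6-fold higher number from compound 1 to compound 2 (0.94 log units; beyond the scatter). Compound 3 removes pyrimidin-5-yl again, though the group entering is thiophen-2-yl and not 3-chlorophenyl, so the step is expected to run partly back toward compound 1 rather than fully. The step from compound 2 to compound 3 is therefore expected to be a 4.2-fold lower number from compound 2 to compound 3 (0.63 log units; beyond the scatter), a lower number. Compound 3 is estimated at 4500 nM in this assay, with a range from 1500 nM to 13000 nM.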

Compound 3, half-maximal effective concentration: 360 nM
The estimate for compound 3 lay 13-fold (1.10 log units) above the measured number; measured number outside the range, below it.
By their numbers in this assay, from the lowest: compound 3; then compound 1; then compound 2.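

In this assay, this saturated ring carbon of the three-membered ring turns out to hold more than the first two compounds suggested. Until now, 3-chlorophenyl had the lowest number, but thiophen-2-yl goes past it, with a 6.1-fold lower number from compound 1 to compound 3 (0.79 log units; beyond the scatter), so the chlorinated six-membered ring is not the best group seen here. The exchange of pyrimidin-5-yl for thiophen-2-yl, with a 53-fold lower number from compound 2 to compound 3 (1.72 log units; beyond the scatter), is the largest step among the three compounds, and it shows that the number at this position can shift widely with a single aromatic ring exchanged while the rest of the core stays the same. Nothing available here accounts for this order among the three groups.

With only three groups at this position, the compounds shown cannot separate the effect of ring size from that of the hetero atoms, since thiophen-2-yl differs from pyrimidin-5-yl in both. On these data alone, a furyl group or an unsubstituted phenyl on the same carbon would bear on that question, and it also remains open whether a chlorine on the thiophene ring would lower the number further.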